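The source may hold more compounds than are shown below. What is called first, only, known or untested is meant among the compounds shown, and "the series" means these compounds.

Measured in a functional assay on CCRF-CEM cells (Homo sapiens) for cytotoxicity, read by XTT assay, with a stated time of 3 days; on this read-out lower numbers stand for stronger inhibition and higher numbers for weaker inhibition
- compound 1 `OC[C@H]1O[C@@H](n2cc(F)c3c(-c4ccccc4)ncnc32)[C@H](O)[C@@H]1O` gives 3100 nM
- compound 2 `OC[C@H]1O[C@@H](n2cc(F)c3c(-c4cccs4)ncnc32)[C@H](O)[C@@H]1O` gives 270 nM
- compound 3 `OC[C@H]1O[C@@H](n2cc(F)c3c(-c4c[nH]cn4)ncnc32)[C@H](O)[C@@H]1O` gives 1800 nM

Compound 3 stands second highest of these three numbers, at 1800 nM. Two measured steps place it: a 1.7-fold lower number from compound 1 to compound 3 (0.24 log units; within the scatter), and a 6.7-fold higher number from compound 2 to compound 3 (0.82 log units; beyond the scatter).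

Compound 4 `OC[C@H]1O[C@@H](n2cc(F)c3c(-c4ccsc4)ncnc32)[C@H](O)[C@@H]1O` keeps the shared core and changes one group: thiophen-3-yl in place of 1H-imidazol-4-yl on an aromatic carbon. In words, thiophen-3-yl takes the place of 1H-imidazol-4-yl on an aromatic carbon.

No thiophen-3-yl group has been measured on this core, so the best guide is compound 2, whose thiophen-2-yl is the closest group to it among those tested. The most relevant evidence is a 6.7-fold higher number from compound 2 to compound 3 (0.82 log units; beyond the scatter), supported by an 11-fold lower number from compound 1 to compound 2 (1.06 log units; beyond the scatter). If thiophen-3-yl behaves much like thiophen-2-yl, the step from compound 3 should run roughly in reverse, towards a lower number. The data do not show whether the two thiophene groups behave alike, so a somewhat smaller step is the cautious expectation, with a wide range. The expected change is a 4.5-fold lower number from compound 3 to compound 4 (0.65 log units; beyond the scatter). Compound 4 is estimated at 400 nM, with an expected range from 130 nM to 1200 nM.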

Compound 4, half-maximal inhibitory concentration: 560 nM
Beside the measured number, compound 4's estimate is 1.4-fold (0.15 log units) below it, and the stated range covers the measured number.
By their numbers in this assay, from the lowest: compound 2; then compound 4; then compounds 3 and 1 (each within the scatter of the next).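

In this assay, two thiophene groups can now be compared on this aromatic carbon, and the point at which the ring is attached makes a modest difference beyond the scatter (a 2.1-fold higher number from compound 2 to compound 4 (0.32 log units; beyond the scatter)). The lower numbers are also not confined to thiophen-2-yl: thiophen-3-yl stands clearly apart from both 1H-imidazol-4-yl (a 3.2-fold lower number from compound 3 to compound 4 (0.51 log units; beyond the scatter)) and phenyl (a 5.5-fold lower number from compound 1 to compound 4 (0.74 log units; beyond the scatter)), so among these four compounds both thiophene groups give lower numbers than the other two groups. Nothing available here explains why the thiophene groups differ from the other groups or from each other.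

The compounds shown leave open whether the sulfur atom itself matters, which a furan ring, with oxygen in its place, would help to test. They also leave open whether a ring is needed on this carbon at all, since a small group such as an amine or a methyl might give a very different number, and whether a methyl or a chlorine added to the thiophene ring would move the number further.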